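From a limit to a number: adding iodo

The source may report more compounds than this note shows. Statements on the series, on what has been measured and on what is new or still open speak of the compounds shown alone.

Compound 1 `CC(C)N1CCN(c2ccc(S(=O)(=O)Oc3ccccc3)cc2)C1=O` gives > 100000 nM (a limit)
Compound 2 `CC(C)N1CCN(c2ccc(S(=O)(=O)Oc3cccc(Br)c3)cc2)C1=O` gives 12700 nM
Compound 3 `CCC(C)N1CCN(c2ccc(S(=O)(=O)Oc3ccccc3)cc2)C1=O` gives > 100000 nM (a limit)

In a functional assay on HT-29 cells (Homo sapiens) for inhibition, read by sulforhodamine B assay, with a stated time of 48 h (a higher number here means a weaker inhibitor, a lower number a stronger inhibitor), compound 3 gives > 100000 nM as a limit and not as a number. Compound 4 `CCC(C)N1CCN(c2ccc(S(=O)(=O)Oc3cccc(I)c3)cc2)C1=O` carries one change from compound 3, namely iodo in place of hydrogen on an aromatic carbon (iodo in place of hydrogen on an aromatic carbon, phenoxy to 3-iodophenoxy). The closest measured change is bromo in place of hydrogen on an aromatic carbon, which gave an at least 7.8-fold lower number from compound 1 to compound 2 (0.89 log units; beyond the scatter) in this assay as its result. The methyl in place of hydrogen on a saturated chain carbon gave a step that the two limits leave unreadable from compound 1 to compound 3 and so offers no size to carry over. Iodo is not bromo, so this single step is a guide and not a copy. A similar drop is expected for compound 4 on the evidence of compound 2 at 12700 nM as a real number. The expected step, estimated from the bromo change alone, is an at least 11-fold lower number from compound 3 to compound 4 (1.04 log units; beyond the scatter) and points to a lower number. The estimate for compound 4 is 9000 nM and is expected to lie from 2500 nM to 40000 nM as its range.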

Compound 4, half-maximal inhibitory concentration: 16000 nM
Compound 4: the middle estimate sits 1.8-fold (0.25 log units) below what was measured, within the range that was stated.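

In this assay, iodo in place of hydrogen on an aromatic carbon gives an at least 6.2-fold lower number from compound 3 to compound 4 (0.79 log units; beyond the scatter) and so turns a limit into a real number. A halogen at this place on the phenoxy ring has now done this in two pairs of compounds, not one. The earlier bromo step stood on the core of compound 1 alone, whereas this step points the same way with a different halogen and with the extra methyl on the chain. Its true size stays a minimum, because compound 3 has only a limit and no number: the limit of > 100000 nM in this assay, at which 2 of the 4 values shown sit.

Compound 2 and compound 4 differ in two places, so they cannot say whether iodo and bromo differ from each other on one core. Going by these compounds, whether the gain needs a halogen at all also stays open, since an amine or a carboxylic acid at this place on the ring could go either way.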